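The source may hold more compounds than are shown below. What is called first, only, known or untested is meant among the compounds shown, and "the series" means these compounds.

Measured so far in a functional assay on MCF7 cells (Homo sapiens) for inhibition, read by sulforhodamine B assay; a higher number here means a weaker inhibitor, a lower number a stronger inhibitor:
compound 1, `O=C1C(NC2CC2)=CC(=O)c2c1nc1n2[C@H]2OC[C@@H](O)[C@H]2OC1`: > 16000 nM
compound 2, `O=C1C=C(NCc2ccccc2)C(=O)c2c1nc1n2[C@H]2OC[C@@H](O)[C@H]2OC1`: > 8000 nM
compound 3, `CCc1ccc(NC2=CC(=O)c3nc4n(c3C2=O)[C@H]2OC[C@@H](O)[C@H]2OC4)cc1`: 960 nM

Compound 1 carries a cyclopropylamino group on the shared core and gives in this assay only a limit, not a number. Compound 2, with benzylamino, likewise gives only a limit. Two of the three values are thus limits, the limit of > 16000 nM in this assay, at which 1 of the 3 values shown sits, and (the limit of > 8000 nM in this assay, at which 1 of the 3 values shown sits), and compound 3 alone returns a number, with a 4-ethylphenylamino group.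

For the measured compounds named here, the one step that can be sized is an at least 8.3-fold lower number from compound 2 to compound 3 (0.92 log units; beyond the scatter). It points the same way as the change now in question: compound 4, `COc1ccccc1NC1=CC(=O)c2c(nc3n2[C@H]2OC[C@@H](O)[C@H]2OC3)C1=O`, differs from compound 1 by 2-methoxyphenyl in place of cyclopropyl on an amine nitrogen. Here too an aromatic ring of carbon only replaces a small saturated group on the amine nitrogen, with one hydrogen-bond acceptor entering in the methoxy group. Going by the values given here, no measured pair shows the 2-methoxyphenyl group itself, so the size of the gain rests on the single step from compound 2 to compound 3 and on a limit for compound 1.

Compound 4 is therefore expected at 1500 nM, within 400 nM to 8000 nM. As an estimate, that amounts to an at least 10-fold lower number from compound 1 to compound 4 (1.02 log units; beyond the scatter), a clear move to a stronger inhibitor.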

Compound 4, half-maximal inhibitory concentration: 6580 nM
Compound 4: the middle estimate sits 4.4-fold (0.64 log units) below what was measured; the range from low to high includes it.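

For the compounds shown here, replacing cyclopropyl with 2-methoxyphenyl on the amine nitrogen gives an at least 2.4-fold lower number from compound 1 to compound 4 (0.38 log units; beyond the scatter) in this assay, so this position now has a second aromatic ring of carbon only that returns a number rather than a limit. An aromatic ring on this nitrogen does not by itself set the level, however, since in this assay compound 3 gives 960 nM and compound 4 gives 6580 nM, which shows that the groups on the ring also count. The true size of the new step stays unknown because compound 1 gives only a limit of the assay, not a number: the limit of > 16000 nM in this assay, at which 1 of the 4 values shown sits.

Plain phenylamino, 2-ethylphenylamino and 4-methoxyphenylamino groups are absent from the compounds shown, so the identity of the ring substituent cannot be separated from its place on the ring. Also open is how the shared core responds when the same amine nitrogen carries a pyridine ring, or a longer chain ending in a dimethylamino group, since all the rings shown on this nitrogen contain carbon only.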